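Moving the dimethylamino group around the amide-bearing ring

The source may report more compounds than this note shows. Statements on the series, on what has been measured and on what is new or still open speak of the compounds shown alone.

Compound 1 `COc1ccc(C(=O)N[C@H]2CCC[C@H](NC(=O)c3cccc(Cl)c3)C2)cc1`: 266 nM
Compound 2 `CN(C)c1ccc(C(=O)N[C@H]2CCC[C@H](NC(=O)c3cccc(Cl)c3)C2)cc1`: 473 nM

In a functional assay on HEK293 cells for antagonist activity at metabotropic glutamate receptor 5 (Homo sapiens), read by FLIPR and calcium flux (on this read-out higher numbers stand for weaker inhibition and lower numbers for stronger inhibition), compound 2 gives 473 nM, the higher of the two numbers measured, yet the step of a 1.8-fold higher number from compound 1 to compound 2 (0.25 log units; within the scatter) keeps it within the scatter of compound 1. Compound 3 `CN(C)c1cccc(C(=O)N[C@H]2CCC[C@H](NC(=O)c3cccc(Cl)c3)C2)c1` differs from compound 2 by 3-(dimethylamino)phenyl in place of 4-(dimethylamino)phenyl on a carbonyl carbon. Going by the values given here, no measured step concerns such a change; the only recorded step, from compound 1 to compound 2, exchanges one group for another at the same place and is itself small. The estimate therefore assumes no shift beyond the scatter, with a 1.1-fold higher number from compound 2 to compound 3 (0.02 log units; within the scatter) expected. Compound 3 is expected to give about 500 nM in this assay, between 150 nM and 1700 nM.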

Compound 3, half-maximal inhibitory concentration: > 10000 nM
Compound 3: no number, only a limit (the forecaster's own chance of this, stated with the estimate: 5%); middle value at least 20-fold (1.30 log units) away from the limit.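

In this assay compound 3 gives a limit of the assay, not a number: the limit of > 10000 nM in this assay, at which 1 of the 3 values shown sits.
The earlier compounds shown here exchanged one group at a single place, whereas this change shows that the place of the dimethylamino group on the ring matters: 3-(dimethylamino)phenyl in place of 4-(dimethylamino)phenyl gives an at least 21-fold higher number from compound 2 to compound 3 (1.32 log units; beyond the scatter), and in place of 4-methoxyphenyl it gives an at least 37-fold higher number from compound 1 to compound 3 (1.57 log units; beyond the scatter).
The compounds shown leave open whether a methoxy group moved in the same way would bring the same loss. They also leave open how a primary amine or a carboxylic acid would behave at that place.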